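A few compounds are considered here, and "the series" means these few. Any claim that something is new, unique, unknown or untested is made for them only; others in the source may bear on it.

Measured compounds:

Compound 1, `O=C(c1ccc(Cl)cc1)N1CCN(c2nc(=O)c3cc(C(F)(F)F)cc([N+](=O)[O-])c3s2)CC1`: 5.19 ug/mL
Compound 2, `Cc1ccc(C(=O)N2CCN(c3nc(=O)c4cc(C(F)(F)F)cc([N+](=O)[O-])c4s3)CC2)cc1`: 6.7 ug/mL
Compound 3, `O=C(C1CCCC1)N1CCN(c2nc(=O)c3cc(C(F)(F)F)cc([N+](=O)[O-])c3s2)CC1`: 5.34 ug/mL

In a physicochemical assay for solubility, read by HPLC (on this read-out lower numbers stand for lower solubility and higher numbers for higher solubility), these three compounds, which share one core and differ only in the group on the carbonyl carbon, sit close together. Compound 2 holds the highest of the three numbers, yet its neighbours are not far off: a 1.3-fold higher number from compound 1 to compound 2 (0.11 log units; within the scatter) and a 1.3-fold lower number from compound 2 to compound 3 (0.10 log units; within the scatter), both steps within the scatter, so no order among the three can be claimed.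

Compound 4, `O=C(c1ccc(F)cc1)N1CCN(c2nc(=O)c3cc(C(F)(F)F)cc([N+](=O)[O-])c3s2)CC1`, is not yet measured. It differs from compound 2 in one place: fluoro in place of methyl on an aromatic carbon. Within the data shown here, the only measured step that bears on a change at this aromatic carbon is a 1.3-fold higher number from compound 1 to compound 2 (0.11 log units; within the scatter), where chloro gave way to methyl without a movement beyond the scatter. An exchange of methyl for fluoro at the same carbon is therefore expected to leave this assay about where compound 2 stands, with no step beyond the scatter in either direction.

Compound 4 is thus estimated at 5.8 ug/mL, in a range of 2.9 ug/mL to 11.6 ug/mL, meaning an expected step of a 1.2-fold lower number from compound 2 to compound 4 (0.06 log units; within the scatter).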

Compound 4, solubility: 1.69 ug/mL
For compound 4 the middle estimate is 3.4-fold (0.54 log units) above the measured one, outside the stated range (below it).
By their numbers in this assay, from the lowest: compound 4; then compounds 1, 3 and 2 (each within the scatter of the next).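

In this assay, this aromatic carbon, para to a large group, proves sensitive to the exchange: fluoro in place of methyl gives a 4.0-fold lower number from compound 2 to compound 4 (0.60 log units; beyond the scatter), and fluoro in place of chloro gives a 3.1-fold lower number from compound 1 to compound 4 (0.49 log units; beyond the scatter), whereas chloro to methyl had stayed at a 1.3-fold higher number from compound 1 to compound 2 (0.11 log units; within the scatter). The 4-fluorophenyl group also separates from cyclopentyl on the carbonyl carbon, with a 3.2-fold lower number from compound 3 to compound 4 (0.50 log units; beyond the scatter), although 4-chlorophenyl and cyclopentyl had shown no such separation, at a 1.0-fold higher number from compound 1 to compound 3 (0.01 log units; within the scatter). Nothing measured here accounts for fluoro parting from the other groups.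

The compounds shown leave open whether a methoxy group, a nitrile or a plain hydrogen at this carbon would read with fluoro or with methyl and chloro. They also leave open how a morpholine or a piperidine in place of cyclopentyl on the carbonyl carbon would read.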